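A Thiourea Replaces a Benzyl Group on the Shared Core

The source may hold more compounds than are shown below. What is called first, only, known or untested is meant among the compounds shown, and "the series" means these compounds.

Compound 2 `Cc1ccccc1CN1CCc2c(sc(NC(=O)c3ccccc3Cl)c2C(N)=O)C1` carries a 2-methylbenzyl on an amine nitrogen in a ring. In a functional assay on HeLa cells (Homo sapiens) for antiproliferative activity, with a stated time of 24 h (on this read-out higher numbers stand for weaker inhibition and lower numbers for stronger inhibition), compound 2 gives > 50000 nM, which is a limit of the assay rather than a number. This is the limit of > 50000 nM in this assay, at which 1 of the 3 values shown sits. Its close relatives give numbers: compound 1 `NC(=O)c1c(NC(=O)c2ccccc2Cl)sc2c1CCN(Cc1ccccc1)C2` gives 38400 nM in this assay, and compound 3 `NC(=O)c1c(NC(=O)c2ccccc2Cl)sc2c1CCN(C(=S)Nc1ccccc1F)C2` gives 28700 nM. The steps of an at least 1.3-fold higher number from compound 1 to compound 2 (0.11 log units; that floor lies within the scatter) and an at least 1.7-fold lower number from compound 2 to compound 3 (0.24 log units; that floor lies within the scatter) stay within the scatter at their floors, and so does a 1.3-fold lower number from compound 1 to compound 3 (0.13 log units; within the scatter).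

Compound 4 `COc1ccccc1NC(=S)N1CCc2c(sc(NC(=O)c3ccccc3Cl)c2C(N)=O)C1` is not yet measured. Its change from compound 2 is a group of 11 heavy atoms (8 carbon, 1 nitrogen, 1 oxygen, 1 sulfur; one six-membered aromatic ring of carbon only) in place of a group of 8 heavy atoms (8 carbon; one six-membered aromatic ring of carbon only), on an amine nitrogen in a ring. The measured step that bears most directly on it is an at least 1.7-fold lower number from compound 2 to compound 3 (0.24 log units; that floor lies within the scatter), where a group of related make-up entered at the same place, and a 1.3-fold lower number from compound 1 to compound 3 (0.13 log units; within the scatter) was likewise small. The expected step is therefore an at least 1.5-fold lower number from compound 2 to compound 4 (0.19 log units; that floor lies within the scatter), a size that need not rise beyond the scatter. Compound 4 is estimated at 32000 nM, within a range from 12000 nM to 85000 nM.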

Compound 4, half-maximal inhibitory concentration: > 50000 nM
Compound 4 ended at the assay's limit; the forecaster's own chance of this, stated with the estimate: 30%; at least 1.5-fold (0.19 log units) between middle value and limit.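

Compound 4 shows that the thiourea on the amine nitrogen in a ring does not by itself keep a readable number: with methoxy in place of fluoro on the aromatic carbon, the value falls at the limit of the assay. In this assay the result gives an at least 1.7-fold higher number from compound 3 to compound 4 (0.24 log units; that floor lies within the scatter) and an at least 1.3-fold higher number from compound 1 to compound 4 (0.11 log units; that floor lies within the scatter); these are floors only, so the true gaps may be larger, but neither is shown beyond the scatter. The step between compound 2 and compound 4 cannot be read, and limits now make up a large share of this small set: the limit of > 50000 nM in this assay, at which 2 of the 4 values shown sit.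

Left open is whether any group at this place gives a step beyond the scatter. An amine or a carboxylic acid in place of fluoro on that aromatic carbon would bear on this, as would a longer chain on the amine nitrogen in a ring.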